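The compounds below may be only part of what the source reports. "The series", "measured", "known", "first", "only" and "open" are said of these compounds alone.

In a functional assay on PLC-PRF-5 cells (Homo sapiens) for inhibition (on this read-out higher numbers stand for weaker inhibition and lower numbers for stronger inhibition), compound 1 `CNC(=O)c1cc(Oc2ccc(NS(=O)(=O)c3ccc([N+](=O)[O-])cc3)cc2)ccn1` gives > 40000 nM, which is a limit of the assay and not a number. Compound 2 `CNC(=O)c1cc(Oc2ccc(NS(=O)(=O)c3ccc(F)cc3)cc2)ccn1` gives > 40000 nM, likewise only a limit. Compound 3 `CNC(=O)c1cc(Oc2ccc(NS(=O)(=O)c3ccc(C(C)(C)C)cc3)cc2)ccn1` gives > 40000 nM, again a limit. Compound 2 therefore has no exact value to serve as a starting point. Compound 4 `CNC(=O)c1cc(Oc2ccc(NS(=O)(=O)c3ccc4ccccc4c3)cc2)ccn1` differs from it as follows: naphthalen-2-yl in place of 4-fluorophenyl on a sulfonyl sulfur, with naphthalen-2-yl in place of 4-fluorophenyl on a sulfonyl sulfur. The measured changes to this aromatic group are a step that the two limits leave unreadable from compound 1 to compound 2, a step that the two limits leave unreadable from compound 1 to compound 3 and a step that the two limits leave unreadable from compound 2 to compound 3, and none has a readable size. The expected outcome in this assay is a number no higher from compound 2 to compound 4 (the limit leaves the size open), with no clear direction and no step beyond the scatter anticipated. Compound 4 is estimated at 40000 nM, with an expected range of 15000 nM to 80000 nM.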

Compound 4, half-maximal inhibitory concentration: > 40000 nM
Compound 4 ended at the assay's limit; the forecaster's own chance of this, stated with the estimate: 75%; the middle value sits exactly at the limit.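

No step can be read among compound 1, compound 2, compound 3 and compound 4, as each gives only a limit and not a number: the limit of > 40000 nM in this assay, at which 4 of the 4 values shown sit.

The compounds shown leave open whether these aromatic groups on the sulfonyl sulfur differ in inhibition at all.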